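Removing a chloro group: from compound 3 to compound 4

A few compounds are considered here, and "the series" means these few. Any claim that something is new, unique, unknown or untested is made for them only; others in the source may bear on it.

Three compounds share a small bicyclic core carrying an aromatic ring, and all three were tested in a functional assay on T47D cells (Homo sapiens) for cytotoxicity, with a stated time of 72 h, tested at 50 ug/mL; a lower number here means a weaker effect, a higher number a stronger effect of the compound at the concentration tested. Compound 1, `N/N=C1\NCCN1c1ccccc1Cl`, gives 27%. Compound 2, `Cc1cccc(N2CCn3c2n[nH]c(=O)c3=O)c1C`, gives 22%. Compound 3, `N=c1c(=O)[nH]nc2n1CCN2c1cccc(Cl)c1`, gives 31%.

On these numbers compound 3 stands highest of the three, but only in a formal sense: the gap to compound 1, the nearest of the other two, lies within the usual scatter of this kind of measurement, and so does the wider gap to compound 2. The three values are therefore indistinguishable in practice, and none of the compounds can be called more or less active than another.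

Compound 4, `N=c1c(=O)[nH]nc2n1CCN2c1ccccc1`, has not yet been measured. It differs from compound 3 in a single place: hydrogen in place of chloro on an aromatic carbon. For the measured compounds named here, no pair of measured compounds differs in only one place, so there is no measured step to lean on. Given how closely the three measured numbers sit, no step beyond the scatter is expected, in either direction. Compound 4 is therefore estimated to give about 28%, somewhere between 14% and 42%. The expected step of a number 3 percentage points lower from compound 3 to compound 4 (within the scatter) is small and within the scatter.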

Compound 4, a percentage reported as inhibition, at one concentration (the size of the read-out at that concentration, not a potency): 3%
For compound 4 the middle estimate is 25 percentage points above the measured one; measured number below the stated range.
By their numbers in this assay, from the lowest: compound 4; then compounds 2, 1 and 3 (each within the scatter of the next).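

Chloro on this aromatic carbon, meta to a large group, counts in this assay and replacing it with hydrogen gives a number 28 percentage points lower from compound 3 to compound 4 (beyond the scatter) in the only step here that can be read. A single chlorine atom is the whole of what leaves, with no ring, charge, hydrogen-bond donor or acceptor going with it, so even a very small edit at this place can change the read-out by more than the usual scatter. The numbers show that this change matters, but no measurement here bears on why it does.

The compounds shown leave open whether chlorine itself is needed at this place or whether another group, such as fluoro, bromo or methoxy, would restore the read-out of compound 3 in this assay to a similar level. For the compounds shown here, they also leave open whether removing a chloro group would cost as much on another carbon of the ring or on another core, since this single pair is the only evidence for the change.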